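A few compounds are considered here, and "the series" means these few. Any claim that something is new, unique, unknown or untested is made for them only; others in the source may bear on it.

Compounds measured in an assay on isolated protein for inhibition of aldehyde dehydrogenase 1A1 (Homo sapiens), read by spectrophotometry, tested at 10 uM; on this read-out lower numbers stand for less inhibition and higher numbers for more inhibition at the one concentration tested (going by the name of the read-out):
Compound 1 `Cc1cccc(Cn2c(CN3CCN(C(=O)c4cccnc4)CC3)nc3ccccc32)c1` gives 24.5%.
Compound 2 `Cc1cccc(Cn2c(CN3CCN(C(=O)C4CCCC4)CC3)nc3ccccc32)c1` gives 67.5%.

Compound 2 stands highest of the two numbers in this assay; its nearest neighbour is compound 1, and the step of a number 43 percentage points higher from compound 1 to compound 2 (beyond the scatter) separates them, with cyclopentyl in place of pyridin-3-yl on the carbonyl carbon. Compound 3 `CCc1ccc(C(=O)N2CCN(Cc3nc4ccccc4n3Cc3cccc(C)c3)CC2)cc1` differs from compound 2 by 4-ethylphenyl in place of cyclopentyl on a carbonyl carbon. Going by the values given here, the one measured step that bears on this change is a number 43 percentage points higher from compound 1 to compound 2 (beyond the scatter), which exchanged an aromatic six-membered ring for cyclopentyl at the same carbonyl carbon and was large. Among the compounds with values here, compound 3 reverses that exchange in kind, putting an aromatic six-membered ring back where cyclopentyl sits, though with 4-ethylphenyl rather than pyridin-3-yl, so the account has no measured step for the exact group. On this ground a step downward is expected, a number 27.5 percentage points lower from compound 2 to compound 3 (beyond the scatter), roughly following the size of that one step. Compound 3 is therefore estimated at 40%, in a range from 20% to 65%.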

Compound 3, a percentage reported as inhibition, at one concentration (the size of the read-out at that concentration, not a potency): 67%
The estimate for compound 3 lay 27 percentage points below the measured number; the measured number lies above the stated range.
By their numbers in this assay, from the lowest: compound 1; then compounds 3 and 2 (each within the scatter of the next).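

In this assay the change from cyclopentyl to 4-ethylphenyl on the carbonyl carbon gives a number 0.5 percentage points lower from compound 2 to compound 3 (within the scatter) and so shows that an aromatic six-membered ring at this position does not in itself go with a low number. The comparison with the pyridin-3-yl compound gives a number 42.5 percentage points higher from compound 1 to compound 3 (beyond the scatter) and so ties the low number of compound 1 to pyridin-3-yl rather than to aromatic rings at this position in general. Nothing at hand gives a reason for either step.

Pyridin-3-yl and 4-ethylphenyl differ both in the ring nitrogen and in the ethyl group, and the compounds shown do not tell which of the two accounts for the gap. Plain phenyl would speak to that, and a carboxylic acid or an amine in place of the ethyl group remains an open case.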